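Allyl Ether of Compound 1: An Expected Outcome

The compounds below may be only part of what the source reports. "The series", "measured", "known", "first", "only" and "open" are said of these compounds alone.

Measured so far in a functional assay on HUVEC cells (Homo sapiens) for antiproliferative activity, read by MTT assay, with a stated time of 24 h; a lower number here means a stronger inhibitor, a higher number a weaker inhibitor:
- compound 1, `C=CCc1cc(-c2cccc([N+](=O)[O-])c2)ccc1O`, reaches only the assay limit of > 100000 nM
- compound 2, `C=CCc1cc(-c2cccc(C(F)(F)F)c2)ccc1O`, gives 76000 nM
- compound 3, `C=CCc1cc(-c2cccc([N+](=O)[O-])c2)cc(CC=C)c1O`, reaches only the assay limit of > 100000 nM

Compound 1 stands at a limit, not at a number, so its true value is known only as lying beyond that limit. The unmeasured compound 4, `C=CCOc1ccc(-c2cccc([N+](=O)[O-])c2)cc1CC=C`, differs from compound 1 in one place: allyl in place of hydrogen on an oxygen on an aromatic ring.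

Two measured steps start from compound 1. The step of an at least 1.3-fold lower number from compound 1 to compound 2 (0.11 log units; that floor lies within the scatter) is at its floor within the scatter, and the step that the two limits leave unreadable from compound 1 to compound 3 cannot be read at all, since both ends are limits. For the measured compounds named here, neither step changes the hydroxy group itself, so no measured step directly mirrors the change to compound 4. What the data do show is the limit of > 100000 nM in this assay, at which 2 of the 3 values shown sit, and compound 2 sits close to it as well. The expectation for compound 4 is therefore no step beyond the scatter, with a high chance that only a limit is reported. Compound 4 is expected to give about 150000 nM in this assay, within 50000 nM to 600000 nM. This estimate means a step that the limit leaves unreadable from compound 1 to compound 4.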

Compound 4, half-maximal inhibitory concentration: > 100000 nM
Compound 4 ended at the assay's limit (the forecaster's own chance of this, stated with the estimate: 70%); the middle value is on the limit's open side.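

Compound 1 and compound 4 both sit at a limit of this assay, so the step between them cannot be read: the limit of > 100000 nM in this assay, at which 3 of the 4 values shown sit.

The compounds shown leave open whether changing hydroxy to allyloxy alters the result for a compound that gives a number rather than a limit, such as compound 2.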